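The source may hold more compounds than are shown below. What is called first, only, known or untested is meant among the compounds shown, and "the series" means these compounds.

Compound 1 `Cc1cccc(NC(=O)N[C@H](C)c2ccccc2)c1` was tested in an ADME assay on the whole organism with Oryza sativa as the target, tested at 1 uM (on this read-out higher numbers stand for a weaker effect at the one concentration tested and lower numbers for a stronger effect), and gives 98%. Its mirror-image form, compound 2 `Cc1cccc(NC(=O)N[C@@H](C)c2ccccc2)c1`, gives 100%, and compound 3 `CCCCCc1ccc(NC(=O)N[C@H](C)c2ccccc2)cc1` gives 101%. Going by the values given here, the step of a number 2 percentage points higher from compound 1 to compound 2 (within the scatter) is the only single change measured so far, resting on (the fact that compounds 1 and 2 differ only in the configuration as drawn). Compound 1 thus sits within the scatter of both compound 2 and compound 3, all three close to the top of the scale.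

Compound 4 `C[C@@H](NC(=O)Nc1cccc(F)c1)c1ccccc1` has not yet been measured. Compared with compound 1 it shows (fluoro in place of methyl on an aromatic carbon). Among the compounds with values here, no measured step swaps one aromatic substituent for another, so the stereo step offers no guide, and the three measured compounds simply cluster together. Compound 4 is therefore expected to show no step beyond the scatter, with a number 1 percentage points higher from compound 1 to compound 4 (within the scatter) as the expected step. Compound 4 is estimated at 99%, within a range from 91% to 106%.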

Compound 4, a percentage reported as activity, at one concentration (the size of the read-out at that concentration, not a potency): 95%
For compound 4 the middle estimate is 4 percentage points above the measured one, within the range that was stated.
By their numbers in this assay, from the lowest: compounds 4, 1, 2 and 3 (each within the scatter of the next).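

In this assay, fluoro in place of methyl on this aromatic carbon gives a number 3 percentage points lower from compound 1 to compound 4 (within the scatter). Going by these compounds alone, this is the first measured swap of one aromatic substituent for another, and it does not move the read-out beyond the scatter, so the two groups cannot be told apart here. No available evidence bears on this swap. As far as these compounds go, whether an amine or a carboxylic acid on this aromatic carbon would give a step beyond the scatter remains open.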